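A few compounds are considered here, and "the series" means these few. Any claim that something is new, unique, unknown or untested is made for them only; others in the source may bear on it.

Working notes on the series. Compound 1 `CN(C[C@H]1Cc2c(cccc2N2CCN3CCC[C@H]3C2)CN1)[C@H]1CCCc2cccnc21` has been tested in a functional assay on CCRF-CEM cells for agonist activity at C-X-C chemokine receptor type 4 (Homo sapiens), read by calcium flux, with a stated time of 25 min (on this read-out lower numbers stand for an effect already at smaller amounts and higher numbers for an effect only at larger amounts of compound), where compound 1 gives > 30000 nM, a limit of the assay and not a number. Compound 2 `FC1(F)CCC(CN(C[C@H]2Cc3c(cccc3N3CCNCC3)CN2)[C@H]2CCCc3cccnc32)CC1` in this assay likewise returns a limit, with compound 2 at > 30000 nM. Among the measured compounds shown here, both results sit at the limit of > 30000 nM in this assay, at which 2 of the 2 values shown sit, so no step between measured compounds can be drawn, and nothing is known about where either of them would fall if a number were reached.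

Compound 3 `CN(C[C@H]1Cc2c(cccc2N2C[C@@H]3C[C@H]2CN3)CN1)[C@H]1CCCc2cccnc21` is the next compound to be measured. It differs from compound 1 by a group of 7 heavy atoms (5 carbon, 2 nitrogen; 2 five-membered non-aromatic rings with 1 hetero atom each) in place of a group of 9 heavy atoms (7 carbon, 2 nitrogen; one five-membered non-aromatic ring with 1 hetero atom, one six-membered non-aromatic ring with 2 hetero atoms), on an aromatic carbon. With both measured compounds sitting at the limit, no direction for this change can be read from the series. The expectation is that the step of a number no higher from compound 1 to compound 3 (the limit leaves the size open) stays within the scatter. Compound 3 is expected in this assay at 30000 nM, in a range from 10000 nM to 100000 nM, most likely again reported only as a limit.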

Compound 3, half-maximal effective concentration: > 30000 nM
Compound 3: no number, only a limit (the forecaster's own chance of this, stated with the estimate: 80%); the middle value lies on the limit itself.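

Among the compounds shown here, compound 3, like compound 1, returns only a limit in this assay, so no step between compound 1 and compound 3 can be read: the limit of > 30000 nM in this assay, at which 3 of the 3 values shown sit. The compounds shown leave open where any of them would fall if a number were reached.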